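The source may hold more compounds than are shown below. What is called first, only, known or untested is meant among the compounds shown, and "the series" means these compounds.

Two compounds of the shared core have numbers in a functional assay on A498 cells (Homo sapiens) for cytotoxicity, read by sulforhodamine B assay, with a stated time of 48 h, tested at 0.001 uM (a higher number here means a weaker effect of the compound at the concentration tested, a lower number a stronger effect), so far. Compound 1 `COc1cc(C)cc(-c2c(-c3ccnc(-c4ccc(C(C)=O)cc4)c3)cnn2CC#N)c1` gives 74% there, the lowest of the two values. Going by the values given here, compound 2 `COc1cc(C)cc(-c2nn(CC#N)cc2-c2ccnc(-c3ccc(N(C)C)cc3)c2)c1`, which carries a dimethylamino-substituted phenyl on a core of different attachment, gives 91% in this assay, a number higher than that of compound 1 by more than the usual scatter; no single-site step links the pair, so only the two values themselves can be compared.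

Compound 3 `COc1cc(C)cc(-c2c(-c3ccnc(-c4ccc(N(C)C)cc4)c3)cnn2CC#N)c1` is the unmeasured compound of interest. It differs from compound 1 at one site: dimethylamino in place of acetyl on an aromatic carbon.

Compound 2, the only measured carrier of a dimethylamino group, sits well above compound 1 on the percentage scale, and the change to compound 3 is expected to move in the same direction. The step of a number 11 percentage points higher from compound 1 to compound 3 (beyond the scatter) is estimated as an increase beyond the scatter, though smaller than certain. For compound 3 in this assay the estimated value is 85%, with a range from 70% to 98%.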

Compound 3, a percentage reported as activity, at one concentration (the size of the read-out at that concentration, not a potency): 94%
Estimate against measurement, compound 3: 9 percentage points below, within the range that was stated.
By their numbers in this assay, from the lowest: compound 1; then compounds 2 and 3 (each within the scatter of the next).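

Going by these compounds alone, the first single-site step reads, in this assay, a number 20 percentage points higher from compound 1 to compound 3 (beyond the scatter), so replacing acetyl with dimethylamino on this aromatic carbon, para to a large group, weakens the effect at the concentration tested. Acetyl and dimethylamino have the same heavy-atom and hydrogen-bond acceptor counts, so these counts do not track the step; the exchange does remove the double bond outside the aromatic rings. Nothing measured here bears on why the number moves.

With only two groups shown at this position on the shared core, one pair cannot establish whether acetyl or dimethylamino drives the step. A propanoyl group, a primary amine or a carboxylic acid at the same carbon would show whether the lower number stays with acetyl alone.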